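A few compounds are considered here, and "the series" means these few. Any claim that something is new, unique, unknown or untested is made for them only; others in the source may bear on it.

Compound 3 `COc1ccc(-c2cc(C(=O)Nc3ccc(Oc4ccnc5[nH]ccc45)c(F)c3)ncn2)cc1` gives 4210 nM in a functional assay on A549 cells (Homo sapiens) for cytotoxicity, read by MTT assay, with a stated time of 72 h (on this read-out lower numbers stand for stronger inhibition and higher numbers for weaker inhibition), the smallest of the three numbers recorded. Compound 2 `COc1ccc(-c2cc(C(=O)Nc3ccc(Oc4ccnc5[nH]ccc45)cc3)ncn2)cc1` gives 4410 nM in this assay, and the step of a 1.0-fold lower number from compound 2 to compound 3 (0.02 log units; within the scatter) puts these two within the scatter of each other. Compound 1 `COc1ccc(-c2ccnc(C(=O)Nc3ccc(Oc4ccnc5[nH]ccc45)cc3)n2)cc1` gives 13300 nM in this assay, a gap from compound 3 that lies beyond the scatter. Compound 4 `Cc1ccc(-c2cc(C(=O)Nc3ccc(Oc4ccnc5[nH]ccc45)c(F)c3)ncn2)cc1` differs from compound 3 by methyl in place of methoxy on an aromatic carbon. Among the compounds with values here, no measured step exchanges methoxy for methyl; the only step known, from compound 2 to compound 3, concerns a different change and offers no guide to direction or size here. The account therefore expects a step of a 1.2-fold higher number from compound 3 to compound 4 (0.07 log units; within the scatter) that stays within the scatter. Compound 4 is estimated at 5000 nM in this assay, with a range from 1800 nM to 14000 nM.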

Compound 4, half-maximal inhibitory concentration: 8600 nM
The estimate for compound 4 lay 1.7-fold (0.24 log units) below the measured number, and the stated range covers the measured number.
By their numbers in this assay, from the lowest: compounds 3, 2, 4 and 1 (each within the scatter of the next, the first and the last beyond it).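

The step of a 2.0-fold higher number from compound 3 to compound 4 (0.31 log units; beyond the scatter) in this assay shows that the number responds to the group on this ring, para to a large group. Of the two single changes with a printed step, this is the only one beyond the scatter, and it is modest; the fluoro change, a 1.0-fold lower number from compound 2 to compound 3 (0.02 log units; within the scatter), stayed within it. No measurement at hand explains the difference between methoxy and methyl. From the compounds shown here alone, whether an amine, a chlorine atom or a longer ether chain here would give a lower or higher number remains open.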